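Removing the methoxy group: from compound 3 to compound 4

A few compounds are considered here, and "the series" means these few. Any claim that something is new, unique, unknown or untested is made for them only; others in the source may bear on it.

Compound 3, with the structure `COc1ccccc1-c1n[nH]cc1N1CCNCC1`, was tested in an assay on isolated protein for binding affinity to 5-hydroxytryptamine receptor 3A (Homo sapiens); a lower number here means a stronger inhibitor, a higher number a weaker inhibitor. Compound 3 gives > 10000 nM, which is a limit of the assay rather than a measured number. That limit is the one described by the limit of > 10000 nM in this assay, at which 1 of the 3 values shown sits, and compound 3 is the only one of the three measured compounds that sits there.

Compound 4, with the structure `c1ccc(-c2n[nH]cc2N2CCNCC2)cc1`, has not been measured yet. It differs from compound 3 in one place: hydrogen in place of methoxy on an aromatic carbon.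

For the measured compounds named here, only one measured step speaks to a change on the aromatic ring. Compound 1, `Fc1cccc(-c2n[nH]cc2N2CCCNCC2)c1`, gives 656 nM in this assay, and compound 2, `COc1cccc(-c2n[nH]cc2N2CCCNCC2)c1`, gives 1030 nM. The step of a 1.6-fold higher number from compound 1 to compound 2 (0.20 log units; within the scatter) lies within the scatter, so exchanging one small group for another on that ring did little there. Those two compounds share a different core from compound 3, so the comparison is indirect. Because compound 3 gives only > 10000 nM, the size of the step to compound 4 cannot be fixed from the measurements.

Compound 4 is expected to land near 3000 nM, within a range of 500 nM to 20000 nM, and the estimated step of an at least 3.3-fold lower number from compound 3 to compound 4 (0.52 log units; beyond the scatter) is therefore uncertain in direction.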

Compound 4, inhibition constant: > 10000 nM
Compound 4 gave a limit, no number (the forecaster's own chance of this, stated with the estimate: 30%); middle value at least 3.3-fold (0.52 log units) away from the limit.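

In this assay compound 4 gives > 10000 nM, which is a limit of the assay and not a number. For the compounds shown here, compound 3 also stands at a limit, so no step between compound 3 and compound 4 can be read: the limit of > 10000 nM in this assay, at which 2 of the 4 values shown sit. The compounds shown leave open whether removing the methoxy group changes binding at all.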